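Cytotoxicity notes on the biaryl anilinopyrimidine series

A few compounds are considered here, and "the series" means these few. Any claim that something is new, unique, unknown or untested is made for them only; others in the source may bear on it.

Measured so far:
compound 1, `Cc1cc(-c2cccc(F)c2)cc(C)c1Nc1ccnc(Nc2ccc(C#N)cc2)n1`, 4120 nM
compound 2, `COc1ccccc1-c1cc(C)c(Nc2ccnc(Nc3ccc(C#N)cc3)n2)c(C)c1`, 940 nM
compound 3, `Cc1cc(-c2ccc(C(F)(F)F)cc2)cc(C)c1Nc1ccnc(Nc2ccc(C#N)cc2)n1`, 4160 nM

In an ADME assay on MT4 cells (Homo sapiens) for cytotoxicity, read by MTT assay, with a stated time of 4 days (a lower number here means that less compound is tolerated, a higher number that more compound is tolerated), compound 3 gives the highest of the three numbers, though it sits within the scatter of compound 1 (a 1.0-fold higher number from compound 1 to compound 3 (0.00 log units; within the scatter)) and is separated from compound 2 only by a modest step (a 4.4-fold higher number from compound 2 to compound 3 (0.65 log units; beyond the scatter)). Compound 4, `Cc1cc(-c2c(C)cccc2C)cc(C)c1Nc1ccnc(Nc2ccc(C#N)cc2)n1`, has not yet been measured in this assay; it differs from compound 3 in one place: 2,6-dimethylphenyl in place of 4-(trifluoromethyl)phenyl on an aromatic carbon.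

Among the compounds with values here, the steps that bear on this change are those made at the same aromatic carbon: a 1.0-fold higher number from compound 1 to compound 3 (0.00 log units; within the scatter) and a 4.4-fold higher number from compound 2 to compound 3 (0.65 log units; beyond the scatter), alongside a 4.4-fold lower number from compound 1 to compound 2 (0.64 log units; beyond the scatter). Within the data shown here, two of the three aryl swaps seen so far have moved the number only modestly or not at all, and no measured step involves a 2,6-dimethylphenyl group, so no direction can be read off from the data. The step from compound 3 to compound 4 is therefore expected to be small, a 1.5-fold lower number from compound 3 to compound 4 (0.17 log units; within the scatter), with a leaning toward a somewhat lower number but not clearly beyond the scatter. For compound 4 the number in this assay is estimated at 2800 nM, with a range of 1000 nM to 8000 nM.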

Compound 4, half-maximal cytotoxic concentration: 2590 nM
Compound 4: the middle estimate sits 1.1-fold (0.03 log units) above what was measured; the measured number falls inside the stated range.
By their numbers in this assay, from the lowest: compound 2; then compounds 4, 1 and 3 (each within the scatter of the next).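

In this assay, within the data shown here, a 2,6-dimethylphenyl group at this aromatic carbon stays level with the 4-(trifluoromethyl)phenyl and 3-fluorophenyl groups (a 1.6-fold lower number from compound 3 to compound 4 (0.21 log units; within the scatter); a 1.6-fold lower number from compound 1 to compound 4 (0.20 log units; within the scatter)), so an aryl group of carbon only, without the fluorine atoms, gives no step past the scatter. Only the 2-methoxyphenyl group of compound 2 now stands apart from the other three aryl groups, and the new comparison confirms this (a 2.8-fold higher number from compound 2 to compound 4 (0.44 log units; beyond the scatter)). Nothing measured on hand explains why compound 2 gives the lowest number of the four.

The compounds shown leave open whether that lower number follows the methoxy group itself or holds only for this one aryl group. They also leave open how a phenyl group carrying an amine or a carboxylic acid at this carbon would read in this assay.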